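Spiro-imidazolone glucagon antagonists: lengthening the benzylic side chain

The source may report more compounds than this note shows. Statements on the series, on what has been measured and on what is new or still open speak of the compounds shown alone.

Measured compounds:
compound 1 `CC(C)(C)[C@H]1CC[C@]2(CC1)N=C(c1cccc(C(F)(F)F)c1)C(=O)N2Cc1ccc(C(=O)NCCC(=O)O)cc1` gives 510 nM in a functional assay on CHO cells for antagonist activity at Glucagon receptor (Homo sapiens), read by cAMP accumulation, with stated times of 30 min and 45 min; a lower number here means a stronger inhibitor, a higher number a weaker inhibitor
compound 2 `CC(C)[C@H](c1ccc(C(=O)NCc2nn[nH]n2)cc1)N1C(=O)C(c2cc(Cl)cc(Cl)c2)=N[C@]12CC[C@@H](C(C)(C)C)CC2` gives 2200 nM in this assay

Of the two measured compounds, compound 2 has the higher number in this assay, and its gap to compound 1 lies beyond the usual scatter, so compound 2 is the weaker inhibitor of the pair. Compound 3 `CC(C)CC[C@H](c1ccc(C(=O)NCc2nn[nH]n2)cc1)N1C(=O)C(c2cc(Cl)cc(Cl)c2)=N[C@]12CC[C@@H](C(C)(C)C)CC2` has not yet been measured. It differs from compound 2 in one place: isopentyl in place of isopropyl on a saturated chain carbon bound to an amide-type nitrogen in a ring and an aromatic carbon. Among the measured compounds shown here, no step between measured compounds is available to calibrate this change, so the expectation rests on the structural change alone. A moderate shift toward a lower number, not far beyond the scatter, is expected from compound 2 to compound 3, a 1.8-fold lower number from compound 2 to compound 3 (0.26 log units; within the scatter). For compound 3 in this assay, the estimate is 1200 nM, with a range from 400 nM to 3500 nM.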

Compound 3, half-maximal inhibitory concentration: 150 nM
Compound 3: middle estimate off by 8.0-fold (0.90 log units), on the high side; measured number below the stated range.
By their numbers in this assay, from the lowest: compound 3; then compound 1; then compound 2.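

In this assay, isopentyl in place of isopropyl on a saturated chain carbon bound to an amide-type nitrogen in a ring and an aromatic carbon gives a 15-fold lower number from compound 2 to compound 3 (1.17 log units; beyond the scatter). Among the compounds shown here, this is the first measured step at this position, and it shows that the position responds strongly to the chain it carries, even though the change only takes 3 heavy atoms to 5, with no ring, hydrogen-bond donor, hydrogen-bond acceptor or net charge on either side. No measurement shown here explains the size of this step.

From the compounds shown here alone, whether a longer chain, a cyclohexyl group, an amine or a carboxylic acid at this position would extend or reverse the step remains open. Also open, going by these compounds, is whether isopentyl would give a comparable step on compound 1, which differs from compound 2 in more than one place.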